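The source may report more compounds than this note shows. Statements on the series, on what has been measured and on what is new or still open speak of the compounds shown alone.

Values in a functional assay on HCT-116 cells (Homo sapiens) for inhibition, read by colorimetric assay, with a stated time of 3 days; a lower number here means a stronger inhibitor, a higher number a weaker inhibitor:

- Compound 1 (`O=C(CCCCCCNC(=O)C(O)(O)C(F)(F)F)Nc1ccncc1`) gives 6670 nM
- Compound 2 (`O=C(CCCCCCNC(=O)C(O)(O)C(F)(F)F)Nc1ccc(F)cc1F`) gives 18500 nM
- Compound 3 (`O=C(CCCCCCNC(=O)C(O)(O)C(F)(F)F)Nc1ccccc1`) gives 9140 nM

Compound 3, at 9140 nM, cannot be separated from compound 1 on the measured step, a 1.4-fold higher number from compound 1 to compound 3 (0.14 log units; within the scatter), but it is clear of compound 2 on the other, a 2.0-fold lower number from compound 2 to compound 3 (0.31 log units; beyond the scatter). The next analogue is compound 4 (`O=C(CCCCCCNC(=O)C(O)(O)C(F)(F)F)Nc1ccc(-c2ccccc2)cc1`), which differs from compound 3 as follows: phenyl in place of hydrogen on an aromatic carbon. Phenyl replaces hydrogen on an aromatic carbon, para to a large group.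

All measured steps change the aryl group on the amide-type nitrogen, and they stay small. The largest is a 2.8-fold higher number from compound 1 to compound 2 (0.44 log units; beyond the scatter), and it is only modest. Going by the values given here, the closest precedent is compound 2, with substituents on the phenyl ring, but it carries fluorines and no second ring. Among the compounds with values here, no measured compound carries a second ring, so the direction remains open. The estimated step is a 1.1-fold lower number from compound 3 to compound 4 (0.06 log units; within the scatter), and no shift beyond the scatter is expected in this assay. For compound 4 the estimated value is 8000 nM, with an expected range of 2500 nM to 22000 nM.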

Compound 4, half-maximal inhibitory concentration: 4730 nM
Estimate against measurement, compound 4: 1.7-fold (0.23 log units) above, and the stated range covers the measured number.
By their numbers in this assay, from the lowest: compounds 4, 1 and 3 (each within the scatter of the next); then compound 2.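

In this assay, the step of a 1.9-fold lower number from compound 3 to compound 4 (0.29 log units; within the scatter) stays within the scatter, so phenyl in place of hydrogen on this aromatic carbon, para to a large group, gives no separable change. Compound 1, compound 2 and compound 3 each hold a single ring on the amide-type nitrogen, so they could not show that a second aromatic ring of carbon only can be carried here with no shift beyond the scatter. No measurement at hand bears on why the number behaves this way.

From the compounds shown here alone, whether an amine or a carboxylic acid on this same aromatic carbon would read like phenyl stays open. Also open, going by these compounds, is whether a methoxy group on the added phenyl, or a longer chain in the shared core, would move the number beyond the scatter.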